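A few compounds are considered here, and "the series" means these few. Any claim that something is new, unique, unknown or untested is made for them only; others in the source may bear on it.

Measured so far in a functional assay on MGC-803 cells (Homo sapiens) for cytotoxicity, read by MTT assay, with a stated time of 72 h; a lower number here means a stronger inhibitor, a higher number a weaker inhibitor:
Compound 1 `FC(F)(F)c1ccc(CSc2nc(Nc3ccccc3C(F)(F)F)c3ccccc3n2)cc1` gives a value that is a limit of the assay, > 50000 nM.
Compound 2 `FC(F)(F)c1ccc(CSc2nc(Nc3cccc(C(F)(F)F)c3)c3ccccc3n2)cc1` gives 15100 nM.
Compound 3 `O=[N+]([O-])c1cccc(Nc2nc(SCc3ccc(C(F)(F)F)cc3)nc3ccccc23)c1` gives a value that is a limit of the assay, > 50000 nM.

Compound 3 therefore stands only at a limit, and it shares that position with compound 1, since (the limit of > 50000 nM in this assay, at which 2 of the 3 values shown sit). Going by the values given here, the one readable number among the three belongs to compound 2.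

Compound 4 `Fc1ccc(Nc2nc(SCc3ccc(C(F)(F)F)cc3)nc3ccccc23)cc1Cl` differs from compound 3 in one place: 3-chloro-4-fluorophenyl in place of 3-nitrophenyl on a nitrogen on an aromatic ring.

Among the compounds with values here, two measured steps bear on this change. From compound 2 to compound 3, nitro in place of trifluoromethyl on an aromatic carbon gave an at least 3.3-fold higher number from compound 2 to compound 3 (0.51 log units; beyond the scatter), so removing the nitro group is the move that regained a readable number. The step that the two limits leave unreadable from compound 1 to compound 3 is unreadable, and an at least 3.3-fold lower number from compound 1 to compound 2 (0.51 log units; beyond the scatter) concerns only the position of the trifluoromethyl group. Within the data shown here, no measured pair shows a chloro or fluoro substituent, so the size of the move away from compound 3 is uncertain.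

Compound 4 is therefore expected to give, in this assay, a readable number near that of compound 2 rather than a limit, estimated at 18000 nM with a range from 5000 nM to 50000 nM. This estimate means a step of an at least 2.7-fold lower number from compound 3 to compound 4 (0.44 log units; beyond the scatter).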

Compound 4, half-maximal inhibitory concentration: > 50000 nM
Compound 4: a limit, no number; the forecaster's own chance of this, stated with the estimate: 35%; middle value at least 2.7-fold (0.44 log units) from the limit.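

In this assay compound 4 stands at a limit, > 50000 nM, and gives no number. Replacing 3-nitrophenyl on this nitrogen is therefore not enough to give a readable value, and the change from 3-(trifluoromethyl)phenyl to 3-chloro-4-fluorophenyl gives an at least 3.3-fold higher number from compound 2 to compound 4 (0.51 log units; beyond the scatter), so among the four groups shown at this place only the 3-(trifluoromethyl)phenyl of compound 2 yields a number. The steps to compound 4 from compound 1 and from compound 3 cannot be read, and the series now sits mostly at one ceiling: the limit of > 50000 nM in this assay, at which 3 of the 4 values shown sit.

Going by these compounds alone, how far compound 1, compound 3 and compound 4 lie past that limit stays open, so these three cannot be ranked against one another, and the single readable value of compound 2 gives no trend among the groups on this nitrogen. Also open, from the compounds shown here alone, is whether a methoxy group, a nitrile, a dimethylamino group or a carboxylic acid on this phenyl ring, or a plain phenyl without any substituent, would give a readable number in this assay.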